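Aryl group exchange at the shared core: furan-3-yl analogue

The source may hold more compounds than are shown below. What is called first, only, known or untested is meant among the compounds shown, and "the series" means these compounds.

Measured in an assay on NIH3T3 cells for inhibition of Sonic hedgehog protein (Mus musculus), read by a luciferase reporter, with a stated time of 48 h; on this read-out higher numbers stand for weaker inhibition and lower numbers for stronger inhibition:
compound 1 `Cc1cnc(Nc2ccc(C(=O)Nc3c(C)cccc3C)cc2)nc1-c1ccc(OC(F)(F)F)cc1`: 1.3 nM
compound 2 `Cc1cnc(Nc2ccc(C(=O)Nc3c(C)cccc3C)cc2)nc1-c1cccc(OC(F)(F)F)c1`: 1.2 nM
compound 3 `Cc1ccc(-c2nc(Nc3ccc(C(=O)Nc4c(C)cccc4C)cc3)ncc2C)cc1`: > 500 nM

Compounds 1 and 2 sit within the scatter of each other (a 1.1-fold lower number from compound 1 to compound 2 (0.03 log units; within the scatter)). For compound 3 the value > 500 nM is a limit of this assay, not a number (the limit of > 500 nM in this assay, at which 1 of the 3 values shown sits). Compound 3 therefore stands at the weak end of the three, set apart by large steps: an at least 380-fold higher number from compound 1 to compound 3 (2.58 log units; beyond the scatter) and an at least 410-fold higher number from compound 2 to compound 3 (2.61 log units; beyond the scatter).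

Compound 4 `Cc1cnc(Nc2ccc(C(=O)Nc3c(C)cccc3C)cc2)nc1-c1ccoc1` differs from compound 3 by furan-3-yl in place of 4-methylphenyl on an aromatic carbon. Among the measured compounds shown here, no measured step covers furan-3-yl; the two large steps concern the exchange of trifluoromethoxyphenyl for methylphenyl, and compound 4 likewise carries no trifluoromethoxy group. In this assay compound 4 is therefore expected to stay weak, near the limit, with an estimated 1000 nM and a range 200 nM to 5000 nM. The step is expected to be a step that the limit leaves unreadable from compound 3 to compound 4, no more than modest in either direction.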

Compound 4, half-maximal inhibitory concentration: 15.7 nM
Compound 4: the middle estimate sits 64-fold (1.80 log units) above what was measured, outside the stated range (below it).
By their numbers in this assay, from the lowest: compounds 2 and 1 (each within the scatter of the next); then compound 4. At a limit, above all of these: compound 3.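

Compound 3 stands at a limit of this assay, not at a number: the limit of > 500 nM in this assay, at which 1 of the 4 values shown sits. Lack of trifluoromethoxy alone therefore does not put a compound at the weak end at this position, as furan-3-yl in place of 4-methylphenyl gives an at least 31-fold lower number from compound 3 to compound 4 (1.50 log units; beyond the scatter). Furan-3-yl still falls short of both trifluoromethoxyphenyl groups, with a 13-fold higher number from compound 2 to compound 4 (1.12 log units; beyond the scatter) and a 12-fold higher number from compound 1 to compound 4 (1.08 log units; beyond the scatter).

As far as these compounds go, whether the gain follows the ring oxygen, the five-membered ring or the absence of the 4-methyl group stays open. Also open, from the compounds shown here alone, is how thiophen-3-yl, plain phenyl or 4-methoxyphenyl would read here.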